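Compound 4 and a stability reading still to come

The compounds below may be only part of what the source reports. "The series", "measured", "known", "first", "only" and "open" are said of these compounds alone.

Measured so far in an ADME assay on microsomes from liver (Mus musculus) for metabolic stability, read by LC-MS, with a stated time of 30 min, tested at 1 uM; a lower number here means that less of the compound is left, a higher number that more of the compound is left

Compound 1 (`O=C(NCc1ccc(S(=O)(=O)c2ccccc2)cc1)c1nc2cnccc2[nH]1`) gives 7.3%

Compound 2 (`O=C(NCc1ccc(S(=O)(=O)N2CCCCC2)cc1)c1cc2cnccc2s1`) gives "below limit of detection" (no number reported)

Compound 3 (`O=C(NCc1ccc(S(=O)(=O)N2CCCCC2)cc1)c1cc2ccncc2[nH]1`) gives "below limit of detection" (no number reported)

Compound 1 is the only one of the three with a number, and that number, 7.3%, sits low on the scale, with little of the compound left. The entries for compound 2 and compound 3 carry no number, so they offer nothing to compare with it. Among the measured compounds shown here, no measured pair in this small set gives a step to lean on.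

Compound 4 (`O=C(NCc1ccc(S(=O)(=O)c2ccccc2)cc1)c1ccc2nncn2c1`) has not yet been measured in this assay. It holds the same atoms as compound 1, joined differently: a group of 9 heavy atoms (6 carbon, 3 nitrogen; one five-membered aromatic ring with 3 hetero atoms, one six-membered aromatic ring with 1 hetero atom) in place of a group of 9 heavy atoms (6 carbon, 3 nitrogen; one five-membered aromatic ring with 2 hetero atoms, one six-membered aromatic ring with 1 hetero atom), on a carbonyl carbon. The change lies on a carbonyl carbon, and the rest of the molecule stays the same.

For the measured compounds named here, with no measured step as a guide, the expectation rests on compound 1 at 7.3% alone. The expected change is a small rise that stays within the usual scatter, estimated as a number 4.7 percentage points higher from compound 1 to compound 4 (within the scatter), although a larger move cannot be ruled out. For compound 4 the estimate is 12%, with an expected range from 2% to 40%.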

Compound 4, percent of the compound remaining: 47%
Beside the measured number, compound 4's estimate is 35 percentage points below it; the whole stated range lies below it.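

In this assay, among the compounds shown here, the exchange on the carbonyl carbon gives the only readable step in this set, a number 39.7 percentage points higher from compound 1 to compound 4 (beyond the scatter). This shows that, with the rest of the molecule unchanged, a change at this position, on a carbonyl carbon whose other neighbours are amide-type nitrogen, can shift the read-out well beyond the scatter. The step comes with no atom added or removed: the entering group has one five-membered aromatic ring with 3 hetero atoms where the leaving group has 2, and it has 0 hydrogen-bond donors and 3 hydrogen-bond acceptors against 1 and 2. No measurement available here indicates which of these differences accounts for the step.

The compounds shown leave open whether the group in compound 4 would give a similar step with the rest of the molecule of compound 2 or compound 3, neither of which has a number in this assay. They also do not show what a single pyridine ring or a carboxylic acid would give on the same carbonyl carbon.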